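Swapping the Propoxypyrimidine Arm for a Dimethoxytriazine

The source may hold more compounds than are shown below. What is called first, only, known or untested is meant among the compounds shown, and "the series" means these compounds.

Measured so far:
compound 1, `CCCOc1ccnc(N2CCN(c3nc(N)c4cc(OC)c(OC)cc4n3)CC2)n1`, gives 0.32 nM in an assay on brain for binding affinity to Adrenergic receptor alpha-1 (Rattus norvegicus); a lower number here means a stronger inhibitor, a higher number a weaker inhibitor
compound 2, `CCCOc1cc(N2CCN(c3nc(N)c4cc(OC)c(OC)cc4n3)CC2)ncn1`, gives 0.36 nM in this assay

Compound 2 holds the higher of the two numbers, but its nearest neighbour, compound 1, lies only a 1.1-fold higher number from compound 1 to compound 2 (0.05 log units; within the scatter) away, so the two cannot be ranked against each other. Compound 3, `COc1nc(OC)nc(N2CCN(c3nc(N)c4cc(OC)c(OC)cc4n3)CC2)n1`, is the next member: it differs from compound 2 by 4,6-dimethoxy-1,3,5-triazin-2-yl in place of 6-propoxypyrimidin-4-yl on an amine nitrogen in a ring. Among the measured compounds shown here, only one measured step bears on this change, the exchange of one propoxy-bearing pyrimidine for another on the same ring nitrogen, a 1.1-fold higher number from compound 1 to compound 2 (0.05 log units; within the scatter), which left the number essentially unchanged. That step suggests the shared core tolerates variation in this aromatic arm, but it says nothing about a ring with an added hetero atom or about methoxy groups replacing the propoxy chain, so the present change is less well covered. The expectation for compound 3 in this assay is therefore a modest step, a 1.7-fold higher number from compound 2 to compound 3 (0.22 log units; within the scatter), most likely toward a somewhat higher number but possibly none beyond the scatter. Compound 3 is estimated at 0.6 nM, within a range from 0.15 nM to 2.5 nM.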

Compound 3, inhibition constant: 0.08 nM
The estimate for compound 3 lay 7.5-fold (0.88 log units) above the measured number; the measured number lies below the stated range.
By their numbers in this assay, from the lowest: compound 3; then compounds 1 and 2 (each within the scatter of the next).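

In this assay, the group on this amine nitrogen turns out to do more than tolerate variation: the exchange between the two propoxypyrimidines stayed within the scatter, but 4,6-dimethoxy-1,3,5-triazin-2-yl gives a 4.5-fold lower number from compound 2 to compound 3 (0.65 log units; beyond the scatter), and against the other propoxypyrimidine it gives a 4.0-fold lower number from compound 1 to compound 3 (0.60 log units; beyond the scatter). Both steps lie beyond the scatter, so this position can move the number even when the entering and leaving groups have the same count of heavy atoms, and the move here is toward a stronger inhibitor. Nothing measured here accounts for the drop in the number.

This change altered two things at once, the ring gaining a hetero atom and two methoxy groups replacing one propoxy chain, so the compounds shown leave open which of the two carries the step, a question that a dimethoxypyrimidine or a propoxy-bearing triazine would help to separate. Also open, going by these compounds, is how the number would respond if an amine or a longer chain such as butoxy stood in place of a methoxy group on the triazine.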